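Spiro-piperidine amides: side-chain variation on the glycinamide arm

A few compounds are considered here, and "the series" means these few. Any claim that something is new, unique, unknown or untested is made for them only; others in the source may bear on it.

Two members of the series carry numbers in an assay on HEK293 cells for displacement of a labelled ligand from NPC1-like intracellular cholesterol transporter 1 (Homo sapiens); on this read-out higher numbers stand for weaker inhibition and lower numbers for stronger inhibition. Compound 1 `CC(C)(C)c1ccc(C(=O)N2CCC3(CC2)C(=O)N(CC(=O)N2CCN(S(C)(=O)=O)CC2)CN3c2ccccc2)cc1` gives 19000 nM. Compound 2 `CC(C)(C)OC(=O)NCCCCCNC(=O)CN1CN(c2ccccc2)C2(CCN(C(=O)c3ccc(C(C)(C)C)cc3)CC2)C1=O` gives 13700 nM. Both values sit at the weak end of the scale, and the two numbers lie close to one another.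

Among the measured compounds shown here, compound 3 `COC(=O)CCCNC(=O)CN1CN(c2ccccc2)C2(CCN(C(=O)c3ccc(C(C)(C)C)cc3)CC2)C1=O` has been prepared, but in this assay compound 3 shows only "not determined" (no result reported), so there is no single number for where it stands; the only guide to its likely range is the pair of weak values from compound 1 and compound 2, which share the same core and the glycinamide arm.

Compound 4 `CC(C)(C)c1ccc(C(=O)N2CCC3(CC2)C(=O)N(CC(=O)NCCCCCO)CN3c2ccccc2)cc1` is the next analogue. Relative to compound 3 the change is 2-hydroxyethyl in place of methoxycarbonyl on a saturated chain carbon, three bonds along the chain from an amide-type nitrogen. For the measured compounds named here, no measured step addresses this kind of exchange, so no direction beyond the scatter can be claimed; the expectation is for a result of the same weak order as compound 1 and compound 2, with no step of note in either direction.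

On that basis compound 4 is expected to give about 15000 nM in this assay, within a range of 5000 nM to 50000 nM, with a real chance that only a limit rather than a number is returned.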

Compound 4, half-maximal inhibitory concentration: 9400 nM
Compound 4: the middle estimate sits 1.6-fold (0.20 log units) above what was measured; the range from low to high includes it.
By their numbers in this assay, from the lowest: compounds 4, 2 and 1 (each within the scatter of the next, the first and the last beyond it).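

Among the compounds shown here, on the arm of the shared core, hydroxy in place of (tert-butoxycarbonyl)amino on a saturated chain carbon, five bonds along the chain from an amide-type nitrogen, leaves the read-out in this assay within the scatter (a 1.5-fold lower number from compound 2 to compound 4 (0.16 log units; within the scatter)). (5-Hydroxypentyl)amino in place of 4-(methylsulfonyl)piperazin-1-yl on a carbonyl carbon gives the first step that lies beyond the scatter, and it is a modest one (a 2.0-fold lower number from compound 1 to compound 4 (0.31 log units; beyond the scatter)). The exchange of methoxycarbonyl for 2-hydroxyethyl itself cannot be read, as compound 3 has no number, and nothing measured here speaks to the cause of either step.

Open, from the compounds shown here alone, is whether a carboxylic acid or a primary amine at the end of the chain would read differently from hydroxy in this assay, and whether a chain longer than 5-hydroxypentyl would keep the step from compound 1. Also open, going by these compounds, is whether a plain 4-methylpiperazin-1-yl on the same carbonyl carbon would stay with compound 1 or move toward compound 4.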